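Swapping trifluoromethyl for methyl on a shared core

A few compounds are considered here, and "the series" means these few. Any claim that something is new, unique, unknown or untested is made for them only; others in the source may bear on it.

Compound 1 `CCOC(=O)CNC(=O)[C@H](CS[C@H]1[C@@H]2C(=O)/C(C)=C\C3=C[C@H](C)C[C@@]34O[C@]2(CC1(C)C)[C@@H](C)C4=O)NC(=O)CC[C@H](N)C(=O)O` gives 26000 nM
Compound 2 `CC1=C2CC(C)(C)/C=C/C(=O)/C(C)=C\C3=C[C@H](C)C[C@]3(O2)[C@@]1(O)C(F)(F)F` gives 26000 nM

In an ADME assay on HEK293 cells (Homo sapiens) for cytotoxicity, read by CellTiter-Glo, with a stated time of 72 h (a lower number here means that less compound is needed, a higher number that more compound is needed for the effect), compound 2 gives 26000 nM and stands level with compound 1 at 26000 nM despite their very different structures. Going by the values given here, no measured pair differs in one place only, so the data offer no direct guide to a single change.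

Compound 3 `CC1=C2CC(C)(C)/C=C/C(=O)/C(C)=C\C3=C[C@H](C)C[C@]3(O2)[C@]1(C)O` has not yet been measured. It carries methyl in place of trifluoromethyl on a saturated ring carbon and otherwise matches compound 2. That carbon lies on a five-membered non-aromatic ring with 1 oxygen, part of a fused or bridged system of three rings.

With no measured swap of this kind to draw on, the expectation stays close to compound 2 at 26000 nM and no step beyond the usual scatter is expected in this assay in either direction. The estimated change is a 1.2-fold lower number from compound 2 to compound 3 (0.07 log units; within the scatter) and it remains a rough expectation. For compound 3 the expected value is 22000 nM with 8000 nM to 60000 nM as the estimated span.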

Compound 3, half-maximal effective concentration: 26000 nM
Beside the measured number, compound 3's estimate is 1.2-fold (0.07 log units) below it; low and high end bracket the measured number.
By their numbers in this assay, from the lowest: compounds 1, 2 and 3 (each within the scatter of the next).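

In this assay, going by these compounds alone, the one direct comparison at this position, methyl in place of trifluoromethyl on a saturated ring carbon, gives no change at the digits printed from compound 2 to compound 3 (within the scatter) and so provides what the earlier compounds could not: a reading of a single change with the rest of the molecule held constant. For this pair, the swap between these two groups leaves the amount of compound needed for the effect unchanged, so in this cell test the two groups cannot be told apart at this carbon. No separate measurement here bears on the result.

Still open, from the compounds shown here alone, is whether this position tolerates any group or only these two, which an amine, a carboxylic acid or a longer chain on the same carbon could help to show. A single pair in this assay also cannot tell whether the same swap would leave the number unchanged on another core or in a different kind of test.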